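Bromo for methyl: what to expect of compound 3

The source may hold more compounds than are shown below. What is called first, only, known or untested is meant among the compounds shown, and "the series" means these compounds.

In a functional assay on IMR-32 cells (Homo sapiens) for cytotoxicity, read by sulforhodamine B assay, with a stated time of 48 h (on this read-out higher numbers stand for weaker inhibition and lower numbers for stronger inhibition), compound 1 `O=C(c1cccnc1)c1ccccc1O` gives 33700 nM and compound 2 `Cc1ccc(O)c(C(=O)c2cccnc2)c1` gives 5540 nM as the lower of the two numbers. Compound 3 `O=C(c1cccnc1)c1cc(Br)ccc1O` is not yet measured and departs from compound 2 by bromo in place of methyl on an aromatic carbon with bromo in place of methyl on an aromatic carbon. Among the compounds with values here, only one measured step bears on this, the modest 6.1-fold lower number from compound 1 to compound 2 (0.78 log units; beyond the scatter) for methyl in place of hydrogen, and it says nothing direct about bromo. No shift beyond the scatter is therefore expected in this assay and the estimated step is a 1.2-fold lower number from compound 2 to compound 3 (0.09 log units; within the scatter) with a slight lean to lower numbers. Compound 3 is expected at 4500 nM with an estimated range of 1700 nM to 12000 nM as its likely span.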

Compound 3, half-maximal inhibitory concentration: 23400 nM
Compound 3: middle estimate off by 5.2-fold (0.72 log units), on the low side; measured number above the stated range.
By their numbers in this assay, from the lowest: compound 2; then compounds 3 and 1 (each within the scatter of the next).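

At this position, para to a hydroxy group, bromo does not stand in for methyl in this assay and gives a 4.2-fold higher number from compound 2 to compound 3 (0.63 log units; beyond the scatter) as a step beyond the scatter. Bromo in place of hydrogen gives only a 1.4-fold lower number from compound 1 to compound 3 (0.16 log units; within the scatter) and stays within the scatter, so of the two groups only methyl shifts the number beyond the scatter from that of compound 1. No measurement at hand accounts for this difference between methyl and bromo. Going by these compounds, whether the shift is special to methyl remains open. An ethyl group, a methoxy group or an amine at this position could show whether other groups share it.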